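Aryl variation on the shared core ahead of compound 3

This account rests on a few compounds, and the source may have more. Where it says the series, first, only, none or still open, it means among the compounds named here.

Compound 2 `Clc1ccc(-c2cn3ccnc3c(-c3ccc4ncn(C5CCCCC5)c4c3)n2)cc1` gives 15.3% in a functional assay on MDA-MB-231 cells (Homo sapiens) for inhibition, read by sulforhodamine B assay, with a stated time of 48 h, tested at 10 uM (on this read-out lower numbers stand for less inhibition and higher numbers for more inhibition at the one concentration tested (going by the name of the read-out)), and on the numbers shown it sits alongside compound 1 `c1ccc2c(-c3cn4ccnc4c(-c4ccc5ncn(C6CCCCC6)c5c4)n3)cccc2c1`, which gives 20.8% in this assay; the only measured step, a number 5.5 percentage points lower from compound 1 to compound 2 (within the scatter), lies within the scatter. Compound 3 `FC(F)(F)c1cccc(-c2cn3ccnc3c(-c3ccc4ncn(C5CCCCC5)c4c3)n2)c1` differs from compound 2 in one place: 3-(trifluoromethyl)phenyl in place of 4-chlorophenyl on an aromatic carbon. For the measured compounds named here, only that flat step bears on this change, so no shift beyond the scatter is expected in this assay. The expected step is a number 1.7 percentage points higher from compound 2 to compound 3 (within the scatter). Compound 3 is therefore estimated at 17%, with a range from 5% to 32%.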

Compound 3, a percentage reported as inhibition, at one concentration (the size of the read-out at that concentration, not a potency): 21.8%
Compound 3: the middle estimate sits 4.8 percentage points below what was measured, and the stated range covers the measured number.
By their numbers in this assay, from the lowest: compounds 2, 1 and 3 (each within the scatter of the next).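

In this assay, a third aryl group on this aromatic carbon again gives no step beyond the scatter: a number 6.5 percentage points higher from compound 2 to compound 3 (within the scatter), and a number 1 percentage points higher from compound 1 to compound 3 (within the scatter). Across compound 1, compound 2 and compound 3, naphthalen-1-yl, 4-chlorophenyl and 3-(trifluoromethyl)phenyl therefore cannot be told apart at this position, and all three steps among them are flat. Nothing available explains this flatness.

Open, on these data alone, is whether an amine or a carboxylic acid on this aryl ring would give a step beyond the scatter. Also open, as far as these compounds go, is what replacing the cyclohexyl group, constant in all three compounds, would do.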